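The source may hold more compounds than are shown below. What is called first, only, known or untested is meant among the compounds shown, and "the series" means these compounds.

Measured compounds and their values in the assay:

- compound 1, `CCC(C)(C)Cc1c[nH]c(CCc2ccc(-n3cccn3)cc2)n1`: 113 nM
- compound 2, `CCC(C)(C)Cc1c[nH]c(CCc2ccc(-c3cccc(C#N)n3)cc2)n1`: 115 nM
- compound 3, `c1ccc(-c2ccc(CCc3nc(CC4CCCC4)c[nH]3)cc2)nc1`: 103 nM

In a functional assay on HEK293 cells for agonist activity at Bombesin receptor subtype-3 (Mus musculus), read by luminescence and calcium flux, with a stated time of 10 min (a lower number here means that less compound is needed, a higher number that more compound is needed for the effect), compound 1 gives 113 nM, compound 2 gives 115 nM and compound 3 gives 103 nM. Compound 2 therefore sits among the other two: its number differs from that of compound 1 and from that of compound 3 only by gaps that fall within the usual scatter of repeated measurements, so the three compounds cannot be told apart on potency.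

The compound not yet measured is compound 4, `CCC(C)(C)Cc1c[nH]c(CCc2ccc(-c3cccnc3)cc2)n1`. It differs from compound 2 in one place: pyridin-3-yl in place of 6-cyanopyridin-2-yl on an aromatic carbon. The shared core and the rest of the molecule stay the same.

Among the compounds with values here, one measured step bears on this change. Going a 1.0-fold higher number from compound 1 to compound 2 (0.01 log units; within the scatter), a different ring on the same aromatic carbon, left the number unchanged. Compound 3 also carries a pyridine ring at this position, though with a different side chain on the core, and its value is close to that of compound 2. Nothing in these data points to a change larger than the scatter when the pyridine ring is swapped for pyridin-3-yl, so the expected step of no change at the digits printed from compound 2 to compound 4 (within the scatter) is essentially flat.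

Compound 4 is therefore estimated at 115 nM in this assay, with a likely range from 50 nM to 270 nM.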

Compound 4, half-maximal effective concentration: 97 nM
Beside the measured number, compound 4's estimate is 1.2-fold (0.07 log units) above it; the range from low to high includes it.
By their numbers in this assay, from the lowest: compounds 4, 3, 1 and 2 (each within the scatter of the next).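

In this assay the change to pyridin-3-yl gives a 1.2-fold lower number from compound 2 to compound 4 (0.07 log units; within the scatter) and, starting from the 1H-pyrazol-1-yl compound, gives a 1.2-fold lower number from compound 1 to compound 4 (0.07 log units; within the scatter). With the side chain on the core held constant, three different rings have now been compared on this aromatic carbon, para to a large group, and the numbers do not separate them. Compound 4 also has no nitrile and is the smaller group by heavy atoms, yet it cannot be told apart from compound 2, so among these compounds a nitrile-bearing ring is not needed for a number in this range, and no measurement at hand explains why these rings read alike.

What remains open is whether this position needs an aromatic ring at all, since every compound shown carries one there and none has, for example, a carboxylic acid, an amine or a plain longer chain in its place. It is also open whether pyridin-3-yl would read the same with the different side chain of compound 3, as no step shown tests that ring on that core.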